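Notes on a small chain methylation step in this series

The compounds below may be only part of what the source reports. "The series", "measured", "known", "first", "only" and "open" are said of these compounds alone.

Measured compounds:
- compound 1, `CC(C)c1nc(Cc2c[nH]cn2)c(C(C)C)s1`: 23.8 mg/kg
- compound 2, `CCc1nc(Cc2c[nH]cn2)c(C(C)C)s1`: 25.3 mg/kg
- compound 3, `CCc1sc(Cc2c[nH]cn2)nc1C`: 2.8 mg/kg

In a functional assay on the whole organism (Abdomen) with Mus musculus as the target (a lower number here means that less compound is needed, a higher number that more compound is needed for the effect), compound 1 gives 23.8 mg/kg, compound 2 gives 25.3 mg/kg and compound 3 gives 2.8 mg/kg. Compound 1 differs from compound 2 by methyl in place of hydrogen on a saturated chain carbon bound to an aromatic carbon and a saturated chain carbon. The measured step here is a 1.1-fold lower number from compound 2 to compound 1 (0.03 log units; within the scatter), so the added methyl made no difference that can be told from repeat scatter.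

Compound 3 has the lowest number of the three, and its distance to both compound 1 and compound 2 is beyond the scatter. How the core of compound 3 differs from the core of compound 2 is not broken down here.

Compound 4, `CCc1nc(Cc2c[nH]cn2)sc1CC`, is not yet measured. It differs from compound 3 by methyl in place of hydrogen on a saturated chain carbon bound to an aromatic carbon. This is the same kind of change as from compound 2 to compound 1, not the same: in the earlier pair the saturated chain carbon is bound to an aromatic carbon and a saturated chain carbon, whereas in compound 3 it is bound to an aromatic carbon only.

The step from compound 3 to compound 4 in this assay is expected to be a 1.1-fold higher number from compound 3 to compound 4 (0.03 log units; within the scatter), small like the earlier one, because a 1.1-fold lower number from compound 2 to compound 1 (0.03 log units; within the scatter) lay within the scatter. Compound 4 is therefore estimated at 3 mg/kg, with a likely range from 1.5 mg/kg to 6.5 mg/kg.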

Compound 4, dose for half-maximal effect: > 30 mg/kg
Compound 4: no number, only a limit (the forecaster's own chance of this, stated with the estimate: 5%); at least 10-fold (1.00 log units) between middle value and limit.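

In this assay compound 4 gives > 30 mg/kg, which is a limit of the assay and not a number. The step reads an at least 10-fold higher number from compound 3 to compound 4 (1.02 log units; beyond the scatter), so methyl in place of hydrogen does not carry over from one core to the other at the same size: the same change on two cores in this assay, a 1.1-fold lower number (0.03 log units; within the scatter) from compound 2 to compound 1 and an at least 10-fold higher number (1.02 log units; beyond the scatter) from compound 3 to compound 4, at least 11-fold (1.05 log units) apart, beyond the scatter of two such steps This rests on two pairs only, it gives no upper size for the new step and no cause for the gap, and the data cannot separate the effect of the core from that of the carbon carrying the methyl, which is bound to an aromatic carbon and a saturated chain carbon in the earlier pair and to an aromatic carbon only in the new one: the limit of > 30 mg/kg in this assay, at which 1 of the 4 values shown sits.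

The compounds shown leave open whether a longer chain such as propyl, on a saturated chain carbon bound to an aromatic carbon on the core of compound 3, would read like the methyl to ethyl difference there. They also leave open how an amine or a carboxylic acid at the end of that chain would read in this assay, and whether any such group would behave alike on the core of compound 1.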